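The compounds below may be only part of what the source reports. "The series", "measured", "known", "first", "only" and "open" are said of these compounds alone.

Measured so far in a functional assay on MCF7 cells (Homo sapiens) for inhibition, read by sulforhodamine B assay, with a stated time of 48 h; on this read-out lower numbers stand for stronger inhibition of growth and higher numbers for weaker inhibition of growth:

Compound 1 `COc1ccc(/C=N/NC(=S)NC(C)(C)[C@H]2CC=C(C)CC2)cc1` gives 37700 nM in this assay.

Compound 2 `CC1=CC[C@H](C(C)(C)NC(=S)N/N=C/c2ccc(O)cc2)CC1` gives only a limit of the assay in this assay, > 100000 nM.

Among the measured compounds shown here, the two measured compounds differ in one place, and the step of an at least 2.6-fold higher number from compound 1 to compound 2 (0.42 log units; beyond the scatter) is the only measured step. Compound 2 therefore stands at the weak end of the two numbers shown, and its value is a limit rather than a number, as the line the limit of > 100000 nM in this assay, at which 1 of the 2 values shown sits, records.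

Compound 3 `CC1=CC[C@H](C(C)(C)NC(=S)N/N=C/c2ccc(N(C)C)cc2)CC1` is not yet measured. It differs from compound 2 by dimethylamino in place of hydroxy on an aromatic carbon. The measured step from compound 1 to compound 2 bears on this change, since it concerns the same group on the same aromatic carbon: replacing the methyl on the oxygen by hydrogen gave a modest weakening, with the number moving to the limit of the assay. The change to compound 3 removes the hydroxy altogether and puts in a dimethylamino, so the step of an at least 2.0-fold lower number from compound 2 to compound 3 (0.30 log units; that floor lies within the scatter) is expected to run back toward the value of compound 1, with wide uncertainty because compound 2 is known only as a limit. Compound 3 is estimated at 50000 nM in this assay, with a range from 15000 nM to 150000 nM.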

Compound 3, concentration for total growth inhibition: > 100000 nM
Compound 3 gave a limit, no number; the forecaster's own chance of this, stated with the estimate: 35%; middle value at least 2.0-fold (0.30 log units) away from the limit.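

The change from methoxy to dimethylamino gives an at least 2.6-fold higher number from compound 1 to compound 3 (0.42 log units; beyond the scatter) in this assay, so the loss on leaving compound 1 is now seen with a second group at this place on the aromatic ring. Compound 2 brought a hydrogen-bond donor to this carbon and dimethylamino brings none, so the loss does not depend on the presence of that donor. The step between compound 2 and compound 3 cannot be read, as both values are limits and hydroxy and dimethylamino therefore cannot be ranked against each other, and of the three groups at this place only methoxy gives a number rather than a limit: the limit of > 100000 nM in this assay, at which 2 of the 3 values shown sit.

On these data alone, how far compound 2 and compound 3 lie beyond that limit remains unknown, so neither can be said to have lost the same amount relative to compound 1. As far as these compounds go, it is also open whether the number belongs to methoxy alone or would hold with another group on this carbon, such as ethoxy, a methyl or a fluorine, which would show how narrow the requirement at this place is.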